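Dropping a Trifluoromethyl Group and Cytotoxicity in Hamster Cells

The source may report more compounds than this note shows. Statements on the series, on what has been measured and on what is new or still open speak of the compounds shown alone.

Compound 1 `O=[N+]([O-])c1ccc(-c2nc3cc(C(F)(F)F)ccc3[nH]2)c([N+](=O)[O-])c1` gives 8000 nM.
Compound 2 `CC(=O)Nc1ccc(-c2nc3ccccc3[nH]2)cc1` gives only a limit of the assay, > 100000 nM.
Compound 3 `CC(=O)Nc1ccc(-c2nc3cc(C(F)(F)F)ccc3[nH]2)cc1` gives 53000 nM.

These numbers come from an ADME assay on BHK cells (Mesocricetus auratus) for cytotoxicity, read by MTT assay, with a stated time of 96 h; on this read-out lower numbers stand for higher toxicity in this test and higher numbers for lower toxicity in this test. Of the two measured numbers, compound 1 has the lower and compound 3 the higher one, so compound 1 is the more toxic of the pair; the difference between the two cores is not broken down here.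

From compound 3 to compound 2 the change is hydrogen in place of trifluoromethyl on an aromatic carbon. This step gave an at least 1.8-fold higher number from compound 3 to compound 2 (0.27 log units; that floor lies within the scatter). The step is known only as a floor because compound 2 sits at the limit of > 100000 nM in this assay, at which 1 of the 3 values shown sits.

Compound 4 `O=[N+]([O-])c1ccc(-c2nc3ccccc3[nH]2)c([N+](=O)[O-])c1` carries the same change on the core of compound 1: hydrogen in place of trifluoromethyl on an aromatic carbon. For the measured compounds named here, the place of the change is the same in both pairs, so the step from compound 3 to compound 2 is the only guide. The step from compound 1 to compound 4 is expected to be a 1.9-fold higher number from compound 1 to compound 4 (0.27 log units; within the scatter), resting on an at least 1.8-fold higher number from compound 3 to compound 2 (0.27 log units; that floor lies within the scatter). Compound 4 is therefore estimated at 15000 nM, with a range from 6000 nM to 50000 nM.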

Compound 4, half-maximal cytotoxic concentration: > 100000 nM
Compound 4: no number, only a limit; the forecaster's own chance of this, stated with the estimate: 5%; middle value at least 6.6-fold (0.82 log units) from the limit.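

In this assay compound 4 gives > 100000 nM, which is a limit of the assay and not a number. Hydrogen in place of trifluoromethyl gives an at least 12-fold higher number from compound 1 to compound 4 (1.09 log units; beyond the scatter), so on the core of compound 1 this change goes with clearly lower toxicity in this test, whereas the step on the other core can only be stated as a floor within the scatter. The numbers point the same way on both cores, but they do not show whether the size of the step carries over from one core to the other: the same change on two cores in this assay, an at least 1.8-fold higher number (0.27 log units; that floor lies within the scatter) from compound 3 to compound 2 and an at least 12-fold higher number (1.09 log units; beyond the scatter) from compound 1 to compound 4; the limit leaves it open whether they differ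

The compounds shown leave open how large the step really is on either core, as compound 2 and compound 4 give no number to compare. They also leave open whether another group on that aromatic carbon, such as a chlorine atom, a methyl group or a nitrile, would give results closer to those with hydrogen or to those with trifluoromethyl.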